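Swapping the ring on the amide nitrogen of a naphthamide

This account rests on a few compounds, and the source may have more. Where it says the series, first, only, none or still open, it means among the compounds named here.

Measured compounds:
compound 1 `O=C(c1ccc2ccccc2c1)N(C1CCCC1)[C@@H]1CCNC1` gives 7400 nM
compound 2 `O=C(c1ccc2ccccc2c1)N(C1CCC1)C1CCNCC1` gives > 40000 nM
compound 3 `Cc1c(C(=O)N(CC(C)(C)C)[C@H]2CCNC2)ccc(Cl)c1Cl` gives > 28000 nM

All three were tested in an assay on HEK293 cells for inhibition of sodium-dependent dopamine transporter (Homo sapiens), read by scintillation counting, with a stated time of 5 min; on this read-out higher numbers stand for weaker inhibition and lower numbers for stronger inhibition. For compound 2 the value > 40000 nM is a limit of the assay rather than a number, so compound 2 can only be placed at the weak end of what was seen (the limit of > 40000 nM in this assay, at which 1 of the 3 values shown sits). For compound 3 the value > 28000 nM is likewise a limit (the limit of > 28000 nM in this assay, at which 1 of the 3 values shown sits). Among the measured compounds shown here, compound 1 is the only one with a definite number, 7400 nM.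

The untested compound 4 `O=C(c1ccc2ccccc2c1)N(C1CCC1)[C@@H]1CCNC1` keeps the core of compound 2 and differs from it by one exchange: pyrrolidin-3-yl in place of piperidin-4-yl on an amide-type nitrogen. Compound 1 carries this same pyrrolidin-3-yl group on its amide-type nitrogen and reaches a measurable value, 7400 nM. Compound 4 is therefore expected to move toward stronger inhibition, with the step of an at least 3.3-fold lower number from compound 2 to compound 4 (0.52 log units; beyond the scatter) expected to exceed the scatter, though its size is uncertain since it starts from a limit. Compound 4 is estimated at 12000 nM, within 4000 nM to 40000 nM.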

Compound 4, half-maximal inhibitory concentration: 5800 nM
The estimate for compound 4 lay 2.1-fold (0.32 log units) above the measured number; low and high end bracket the measured number.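

In this assay, among the compounds shown here, pyrrolidin-3-yl in place of piperidin-4-yl on the amide-type nitrogen, with cyclobutyl held fixed, gives an at least 6.8-fold lower number from compound 2 to compound 4 (0.83 log units; beyond the scatter), the first direct look at this exchange, and it yields a definite number. Compound 2 stands at a limit of the assay, so the size of this step is only a minimum: the limit of > 40000 nM in this assay, at which 1 of the 4 values shown sits. With pyrrolidin-3-yl in place, the other ring on that nitrogen makes no clear difference, since cyclobutyl in place of cyclopentyl gives a 1.3-fold lower number from compound 1 to compound 4 (0.11 log units; within the scatter).

The compounds shown cannot separate the change in ring size from the defined stereocentre that enters with pyrrolidin-3-yl. Going by these compounds, how an azetidin-3-yl ring on the same nitrogen, or a cyclohexyl group in place of cyclobutyl, would read also remains open.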